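This account rests on a few compounds, and the source may have more. Where it says the series, first, only, none or still open, it means among the compounds named here.

Values so far in a functional assay on MCF7 cells (Homo sapiens) for antiproliferative activity; on this read-out higher numbers stand for weaker inhibition and lower numbers for stronger inhibition:
- compound 1 `CC(=O)Oc1ccc(C(=O)Nc2cc3ccc(OCC4CCN(C)C4)c(C)c3oc2=O)cc1CC=C(C)C`: 1880 nM
- compound 2 `CC(=O)Oc1ccc(C(=O)Nc2cc3ccc(OCCC4CCCCN4)c(C)c3oc2=O)cc1CC=C(C)C`: 710 nM
- compound 3 `CC(C)=CCc1cc(C(=O)Nc2cc3ccc(OCCC4CCCCN4)c(C)c3oc2=O)ccc1O`: 710 nM

Compound 3 stands level with compound 2, and together they hold the lowest number of the three. Next is compound 4 `CC(C)=CCc1cc(C(=O)Nc2cc3ccc(OCCCN4CCCCC4)c(C)c3oc2=O)ccc1O`, where 3-(piperidin-1-yl)propoxy replaces 2-(piperidin-2-yl)ethoxy ((piperidin-1-yl)methyl in place of piperidin-2-yl on a saturated chain carbon, two bonds along the chain from an oxygen on an aromatic ring). In the shorter reading, this is (piperidin-1-yl)methyl in place of piperidin-2-yl on a saturated chain carbon, two bonds along the chain from an oxygen on an aromatic ring.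

Two measured steps are at hand. The loss of acetyl (no change at the digits printed from compound 2 to compound 3 (within the scatter)) lies at another place and bears only indirectly. Going by the values given here, the step in the same side chain (a 2.6-fold lower number from compound 1 to compound 2 (0.42 log units; beyond the scatter)) is modest and is the only guide to size, although it was measured with the acetyl present and between different groups. Among the compounds with values here, no measured compound carries piperidin-1-yl, so direction is poorly defined. Within the data shown here, the one measured compound without piperidin-2-yl, compound 1 (1880 nM), has the highest number, which leans the expectation slightly upward. In this assay the step is expected to be no larger than that modest one (estimated a 1.2-fold higher number from compound 3 to compound 4 (0.08 log units; within the scatter)). For compound 4 the estimate is 850 nM (expected range 330 nM to 2200 nM).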

Compound 4, half-maximal inhibitory concentration: > 50000 nM
Compound 4: only a limit was reported; the forecaster's own chance of this, stated with the estimate: 3%; middle value at least 58-fold (1.76 log units) from the limit.
By their numbers in this assay, from the lowest: compounds 2 and 3 (each within the scatter of the next); then compound 1. At a limit, above all of these: compound 4.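

In this assay, going by these compounds alone, the change from 2-(piperidin-2-yl)ethoxy to 3-(piperidin-1-yl)propoxy gives an at least 70-fold higher number from compound 3 to compound 4 (1.84 log units; beyond the scatter), a far larger step than the earlier side-chain step, a 2.6-fold lower number from compound 1 to compound 2 (0.42 log units; beyond the scatter), so this side chain is much less tolerant of change than the earlier compounds showed. For compound 4, the entry > 50000 nM is a limit and not a number, so the step has a lower bound only: the limit of > 50000 nM in this assay, at which 1 of the 4 values shown sits. The change alters more than one feature at once: piperidin-2-yl has 6 heavy atoms and 1 hydrogen-bond donor, whereas (piperidin-1-yl)methyl has 7 heavy atoms and 0 hydrogen-bond donors, and the ring is attached through nitrogen rather than carbon.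

The compounds shown leave open which of these differences accounts for the step; 2-(piperidin-1-yl)ethoxy would separate the ring attachment from the longer chain, and 3-(piperidin-2-yl)propoxy would test the longer chain with the original attachment. Also open, going by these compounds, is how 1-methylpiperidin-2-yl on the same chain would read in this assay, since it keeps the carbon attachment and has no hydrogen on the ring nitrogen.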